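Aryl substituent: chloro in place of methoxy

This account rests on a few compounds, and the source may have more. Where it says the series, first, only, none or still open, it means among the compounds named here.

Values in a functional assay on HT-29 cells (Homo sapiens) for antiproliferative activity, read by sulforhodamine B assay, with a stated time of 48 h; on this read-out higher numbers stand for weaker inhibition of growth and lower numbers for stronger inhibition of growth:
compound 1 `Cc1ccc(-c2cc(N3CCC(CCNS(N)(=O)=O)CC3)ncn2)cc1`: 52300 nM
compound 2 `CCCCc1ccc(-c2cc(N3CCC(CCNS(N)(=O)=O)CC3)ncn2)cc1`: 13300 nM
compound 3 `COc1ccc(-c2cc(N3CCC(CCNS(N)(=O)=O)CC3)ncn2)cc1`: 72300 nM

Going by the values given here, compound 3 gives the highest of the three numbers, but its gap to compound 1 lies within the scatter; only the step of a 5.4-fold higher number from compound 2 to compound 3 (0.74 log units; beyond the scatter) is beyond it. Compound 4 `NS(=O)(=O)NCCC1CCN(c2cc(-c3ccc(Cl)cc3)ncn2)CC1` differs from compound 3 by chloro in place of methoxy on an aromatic carbon. Among the compounds with values here, no measured step brings in chloro, so the bearing steps are a 1.4-fold higher number from compound 1 to compound 3 (0.14 log units; within the scatter) and a 5.4-fold higher number from compound 2 to compound 3 (0.74 log units; beyond the scatter), which pair methoxy with the highest numbers and butyl with the lowest. Chloro is expected to behave more like the methyl of compound 1 than like butyl, so a modest drop in this assay is expected, a 1.8-fold lower number from compound 3 to compound 4 (0.26 log units; within the scatter). For compound 4 the estimated value is 40000 nM, with a range of 12000 nM to 120000 nM.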

Compound 4, concentration for 50% growth inhibition: 30500 nM
Estimate against measurement, compound 4: 1.3-fold (0.12 log units) above; the range from low to high includes it.
By their numbers in this assay, from the lowest: compound 2; then compounds 4, 1 and 3 (each within the scatter of the next, the first and the last beyond it).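

In this assay, chloro on the aromatic carbon para to a large group separates from methoxy, with a 2.4-fold lower number from compound 3 to compound 4 (0.37 log units; beyond the scatter), whereas methyl did not. Chloro and methyl stay unresolved, with a 1.7-fold lower number from compound 1 to compound 4 (0.23 log units; within the scatter) as the only comparison between them. Butyl keeps the lowest number of the four, and a 2.3-fold higher number from compound 2 to compound 4 (0.36 log units; beyond the scatter) shows that chloro does not match it.

No measurement on hand gives a reason for these steps. Open, from the compounds shown here alone, is how an amine, a carboxylic acid or a chain longer than butyl at this position would compare with compound 2.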